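The source may hold more compounds than are shown below. What is called first, only, known or untested is meant among the compounds shown, and "the series" means these compounds.

Compound 1, `COc1ccc(-c2cn3ccnc3c(-c3ccc4ncn(C5CCCCC5)c4c3)n2)cc1`: in a functional assay on SF-539 cells (Homo sapiens) for inhibition, read by sulforhodamine B assay, with a stated time of 48 h, tested at 10 uM (on this read-out higher numbers stand for more inhibition at the one concentration tested (going by the name of the read-out) and lower numbers for less inhibition), compound 1 gives -43.4%.
Compound 2, `CC(=O)c1ccc(-c2cn3ccnc3c(-c3ccc4ncn(C5CCCCC5)c4c3)n2)cc1`: in this assay compound 2 gives 2.82%.

Among the measured compounds shown here, compound 2 holds the higher of the two numbers measured so far. For the measured compounds named here, its nearest neighbour is compound 1, and the step between them, a number 46.2 percentage points higher from compound 1 to compound 2 (beyond the scatter), is the one measured step that bears on what follows; it comes from an acetyl in place of methoxy on an aromatic carbon and is large.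

Compound 3, `Brc1ccc(-c2cn3ccnc3c(-c3ccc4ncn(C5CCCCC5)c4c3)n2)cc1`, differs from compound 2 as follows: bromo in place of acetyl on an aromatic carbon

Going by the values given here, no measured step swaps an acetyl for a bromo, so the single step available is only an indirect guide. It shows that exchanging the group on this aromatic carbon can move the read-out by a large amount, with the methoxy well below the acetyl. Bromo is a third group of its own kind, and the data give no direction for it. The step from compound 2 to compound 3 is therefore expected to be moderate and downward, a number 17.8 percentage points lower from compound 2 to compound 3 (beyond the scatter), with wide uncertainty. For compound 3 the expected result in this assay is -15%, within a range from -45% to 15%.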

Compound 3, a percentage reported as inhibition, at one concentration (the size of the read-out at that concentration, not a potency): 24.4%
Compound 3: middle estimate off by 39.4 percentage points, on the low side, and the stated range ends below it.
By their numbers in this assay, from the lowest: compound 1; then compound 2; then compound 3.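

Measured in this assay the change from 4-acetylphenyl to 4-bromophenyl gives a number 21.6 percentage points higher from compound 2 to compound 3 (beyond the scatter) and bromo in place of methoxy gives a number 67.8 percentage points higher from compound 1 to compound 3 (beyond the scatter) on the same carbon. The earlier pair showed only that this aromatic carbon responds to the group it carries, whereas the three groups now fall in an order beyond the scatter, with methoxy lowest, acetyl in the middle and bromo highest, so the acetyl is not the upper end of what this position allows. Bromo reaches the highest number with a single heavy atom and no hydrogen-bond acceptor, so neither the three heavy atoms of the acetyl nor its carbonyl is needed for that number, and nothing available explains the order of the three groups.

The compounds shown leave open whether chloro, fluoro or trifluoromethyl on the same carbon would match bromo, and where an amine or a carboxylic acid would fall in this order. They also leave open whether the order of the three groups would hold at any concentration other than the single one tested.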